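The source may report more compounds than this note shows. Statements on the series, on what has been measured and on what is new or still open speak of the compounds shown alone.

Compound 1 `Oc1ccc(-c2cc(-c3ccccn3)nc(-c3ccccc3Cl)c2)cc1`, compound 2 `Oc1ccc(-c2cc(-c3ccc(Cl)cc3)nc(-c3ccsc3)c2)cc1`, compound 3 `Oc1cccc(-c2cc(-c3ccc(Cl)cc3)nc(-c3ccccn3)c2)c1` and compound 4 `Oc1ccc(-c2cc(-c3ccc(Cl)cc3)nc(-c3ccccn3)c2)cc1` all carry a hydroxyphenyl group and a chlorophenyl group on a shared core, and they differ in the third aromatic group and in where the hydroxyl sits. They were tested in a functional assay on T47D cells (Homo sapiens) for cytotoxicity, read by CCK-8 assay and cell counting, with a stated time of 2 days; on this read-out higher numbers stand for weaker inhibition and lower numbers for stronger inhibition. For compound 1 the entry in this assay reads "not determined" (no result reported), so no number is available for it. In this assay compound 2 gives 5490 nM. Compound 3 gives 13900 nM, the higher of the two numbers available, and its gap to compound 2 lies beyond the usual scatter of repeated measurements, so compound 3 is the weaker inhibitor of that pair.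

Compound 4 is built from the same atoms as compound 3, joined differently: 4-hydroxyphenyl in place of 3-hydroxyphenyl on an aromatic carbon. Within the data shown here, no measured pair differs only in this way, so there is no direct guide to the size of the step. Compound 2 also carries a 4-hydroxyphenyl group and gives 5490 nM, though it differs from compound 3 in the third aromatic group as well, so it is only a loose hint. A modest step toward stronger inhibition is expected, a 1.7-fold lower number from compound 3 to compound 4 (0.24 log units; within the scatter), although a step that stays within the scatter would not surprise. Compound 4 is therefore estimated at 8000 nM, with a range from 3000 nM to 25000 nM.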

Compound 4, half-maximal inhibitory concentration: 25900 nM
The estimate for compound 4 lay 3.2-fold (0.51 log units) below the measured number; measured number above the stated range.
By their numbers in this assay, from the lowest: compound 2; then compounds 3 and 4 (each within the scatter of the next).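

Moving the hydroxyl from 3-hydroxyphenyl to 4-hydroxyphenyl, on the carbon opposite the ring nitrogen, gives a 1.9-fold higher number from compound 3 to compound 4 (0.27 log units; within the scatter), so this assay cannot tell these two placements apart for compounds that also carry pyridin-2-yl and 4-chlorophenyl groups. Compound 4 also forms a single-change pair with compound 2, and pyridin-2-yl in place of thiophen-3-yl gives a 4.7-fold higher number from compound 2 to compound 4 (0.67 log units; beyond the scatter), the first step in this set that clearly moves the read-out toward weaker inhibition, so among these few compounds the choice of this aromatic group counts for more than the hydroxyl position. Nothing available here explains either result, whether the small hydroxyl step or the larger step from the change of aromatic group.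

It remains open whether the hydroxyl position would matter equally little with thiophen-3-yl in place of pyridin-2-yl, since that pairing does not appear among the compounds shown. Going by these compounds, it is also open how the read-out would respond if a methoxy group, an amine or a carboxylic acid took the place of the hydroxyl, or if a plain phenyl ring replaced the pyridin-2-yl group.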